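A few compounds are considered here, and "the series" means these few. Any claim that something is new, unique, unknown or untested is made for them only; others in the source may bear on it.

Measured so far in an assay on CHO cells for antagonist activity at transient receptor potential cation channel subfamily V member 1 (Homo sapiens), read by FLIPR; on this read-out lower numbers stand for stronger inhibition and higher numbers for weaker inhibition:
- Compound 1 `Cc1ccc(CNC(=O)C(C)c2ccc(NS(C)(=O)=O)c(F)c2)c(N2CCC(C)CC2)n1` gives 72.1 nM in this assay.
- Compound 2 `CC1CCN(c2nc(C3CC3)ccc2CNC(=O)C(C)c2ccc(NS(C)(=O)=O)c(F)c2)CC1` gives 0.9 nM in this assay.
- Compound 3 `CC(C(=O)NCc1ccc(C(F)(F)Cl)nc1N1CCCCCC1)c1ccc(NS(C)(=O)=O)c(F)c1` gives 0.5 nM in this assay.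

Compound 3 gives the lowest of the three numbers; compound 2 sits within the scatter of it, while compound 1 lies well beyond. Compound 4 `CC(C(=O)NCc1ccc(C(F)(F)Cl)nc1OCc1ccccc1)c1ccc(NS(C)(=O)=O)c(F)c1` differs from compound 3 by benzyloxy in place of azepan-1-yl on an aromatic carbon. Among the compounds with values here, the only measured step, an 80-fold lower number from compound 1 to compound 2 (1.90 log units; beyond the scatter), concerns a different position of the core and does not bear on this exchange; no measured pair varies the group next to the ring nitrogen, so there is no direct precedent. In this assay the step from compound 3 to compound 4 is expected to be a 10-fold higher number from compound 3 to compound 4 (1.00 log units; beyond the scatter), a moderate rise with wide uncertainty. Compound 4 is therefore estimated at 5 nM, in the range 1 nM to 30 nM.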

Compound 4, inhibition constant: 0.9 nM
Beside the measured number, compound 4's estimate is 5.6-fold (0.74 log units) above it, outside the stated range (below it).
By their numbers in this assay, from the lowest: compounds 3, 2 and 4 (each within the scatter of the next); then compound 1.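

In this assay, benzyloxy in place of azepan-1-yl on the aromatic carbon next to the ring nitrogen gives a 1.8-fold higher number from compound 3 to compound 4 (0.26 log units; within the scatter). With the chloro(difluoro)methyl group kept, this position therefore carries either a seven-membered non-aromatic ring or a six-membered aromatic ring of carbon only, with no difference beyond the scatter. No measured evidence accounts for this equivalence.

Open, on these data alone, is whether a much smaller group here, such as methoxy or a primary amine, keeps the number. Also open, as far as these compounds go, is whether benzyloxy behaves alike beside cyclopropyl in place of chloro(difluoro)methyl.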